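The source may hold more compounds than are shown below. What is called first, only, known or untested is meant among the compounds shown, and "the series" means these compounds.

Measured in a functional assay on SEM cells (Homo sapiens) for cytotoxicity, with a stated time of 72 h; a lower number here means that less compound is needed, a higher number that more compound is needed for the effect:
Compound 1 `C=C[C@@](C)(/C=C/c1ccc(OCc2ccccc2)cc1)CCC=C(C)C`: > 36600 nM
Compound 2 `C=C[C@@](C)(/C=C/c1ccc(O)cc1)CC/C=C(\C)C(=O)OCC`: > 36600 nM
Compound 3 `C=C[C@@](C)(/C=C/c1ccc(Nc2ccccc2)cc1)CCC=C(C)C`: > 36600 nM

Compound 3 stands at > 36600 nM, which is a limit and not a number. It shares this position with the other two compounds: the limit of > 36600 nM in this assay, at which 3 of the 3 values shown sit. Compound 4 `C=C[C@@](C)(/C=C/c1ccc(Nc2ccc(OC)c(F)c2)cc1)CCC=C(C)C` carries 3-fluoro-4-methoxyphenyl in place of phenyl on a nitrogen on an aromatic ring. Within the data shown here, the one measured step that bears on this change is a step that the two limits leave unreadable from compound 1 to compound 3, with anilino in place of benzyloxy on an aromatic carbon. It gives neither a size nor a direction, so no step beyond the scatter can be expected in this assay from these data, and a further limit is the likeliest result. For compound 4 the estimated value is 36600 nM. The expected range for compound 4 runs from 12000 nM to 75000 nM. This estimate means an expected a number no higher from compound 3 to compound 4 (the limit leaves the size open).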

Compound 4, half-maximal effective concentration: > 36600 nM
Compound 4: no number, only a limit; the forecaster's own chance of this, stated with the estimate: 70%; the middle value lies on the limit itself.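

In this assay compound 4 gives > 36600 nM, a limit and not a number, so the step to it from compound 3, itself held at a limit, cannot be read. The compounds shown leave open whether any of these changes alters the effect at all, as all of them share one position: the limit of > 36600 nM in this assay, at which 4 of the 4 values shown sit.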